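A chloro in place of a methoxy in compound 2

A few compounds are considered here, and "the series" means these few. Any claim that something is new, unique, unknown or untested is made for them only; others in the source may bear on it.

Of the compounds shown here, two built on the same core have been measured in a functional assay on HCT-116 cells (Homo sapiens) for cytotoxicity, read by MTT assay, with a stated time of 48 h, in the presence of a further agent that is not named here; a higher number here means that more compound is needed for the effect, a lower number that less compound is needed. Compound 1 (`COc1ccc(-c2cc(NNC(=O)Nc3cc(Cl)nc(Cl)c3)nc3c2cnn3C)cc1`) gives 12300 nM, while compound 2 (`COc1cc(NC(=O)NNc2cc(-c3ccc(F)cc3)c3cnn(C)c3n2)cc(Cl)n1`) gives 75300 nM. Compound 2 therefore stands at the higher of the two numbers, and the gap between them lies beyond the usual scatter. The two compounds differ in more than one place, so their gap cannot be assigned to any single change.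

Compound 3 (`Cn1ncc2c(-c3ccc(F)cc3)cc(NNC(=O)Nc3cc(Cl)nc(Cl)c3)nc21`) follows from compound 2 by one change, chloro in place of methoxy on an aromatic carbon, next to the ring nitrogen: chloro in place of methoxy on an aromatic carbon. This turns the 2-chloro-6-methoxypyridin-4-yl group into 2,6-dichloropyridin-4-yl. Going by the values given here, that group is also carried by compound 1, which reads 12300 nM, and this single comparison is the only guide available. A moderate move toward lower numbers is therefore expected, beyond the scatter but not by much. The expected change is a 3.4-fold lower number from compound 2 to compound 3 (0.53 log units; beyond the scatter). For compound 3 the estimated value in this assay is 22000 nM, with an expected range of 8000 nM to 60000 nM.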

Compound 3, half-maximal effective concentration: 8210 nM
For compound 3 the middle estimate is 2.7-fold (0.43 log units) above the measured one; measured number inside the range.
By their numbers in this assay, from the lowest: compounds 3 and 1 (each within the scatter of the next); then compound 2.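

The change of chloro in place of methoxy, which turns 2-chloro-6-methoxypyridin-4-yl into 2,6-dichloropyridin-4-yl, now has a size of its own in this assay: a 9.2-fold lower number from compound 2 to compound 3 (0.96 log units; beyond the scatter), whereas the earlier pair differed in more than one place and gave no such reading. The other exchange, in which the other aromatic ring carries fluoro rather than methoxy, gives a 1.5-fold lower number from compound 1 to compound 3 (0.18 log units; within the scatter), so with the 2,6-dichloropyridin-4-yl group present it does not separate the two compounds. Of the two single changes now readable among these three compounds, only the one next to the ring nitrogen gives a step beyond the scatter.

From the compounds shown here alone, whether that step belongs to chloro itself or simply to the departure of methoxy stays open, and a hydrogen, a methyl or an amine at the same place would separate the two readings. Going by these compounds, it is also open whether the same exchange gives a step of similar size when the other aromatic ring carries methoxy rather than fluoro. No measurement at hand accounts for the size of the step.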